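Urea nitrogen substituent in the methoxybenzyl triazole series

The compounds below may be only part of what the source reports. "The series", "measured", "known", "first", "only" and "open" are said of these compounds alone.

Compound 3 `CCNC(=O)N1CCN(C(=S)SCc2cn(Cc3ccc(OC)cc3)nn2)CC1` carries an ethyl group on the urea nitrogen of the shared core. In a functional assay on MGC-803 cells (Homo sapiens) for cytotoxicity, read by MTT assay, with a stated time of 72 h (on this read-out lower numbers stand for stronger inhibition and higher numbers for weaker inhibition), compound 3 reaches only the limit of the assay, > 128000 nM, so no number is known for it. Compound 2 `COc1ccc(Cn2cc(CSC(=S)N3CCN(C(N)=O)CC3)nn2)cc1`, the analogue with an unsubstituted urea nitrogen, likewise returns only a limit in this assay, > 128000 nM. Within the data shown here, the one step that connects measured compounds, a step that the two limits leave unreadable from compound 2 to compound 3, cannot be sized because of the limit of > 128000 nM in this assay, at which 2 of the 3 values shown sit. Among the measured compounds shown here, compound 1 `CC(C)NC(=O)N1CCN(C(=S)SCc2cn(Cc3ccc(Cl)cc3)nn2)CC1`, which pairs an isopropyl urea with a chlorobenzyl group, gives 19900 nM in this assay and is the only member with a number; it differs from compound 4 in the benzyl substituent, and no step for that pair is known.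

Compound 4 `COc1ccc(Cn2cc(CSC(=S)N3CCN(C(=O)NC(C)C)CC3)nn2)cc1` is obtained from compound 3 by methyl in place of hydrogen on a saturated chain carbon bound to an amide-type nitrogen and a saturated chain carbon. For the measured compounds named here, no measured step bears directly on this change. Compound 3 stands at the limit, and most of the series sits there. A move from the ethyl to the isopropyl urea is expected to leave compound 4 near that limit, with a modest gain at most, giving an expected at least 1.4-fold lower number from compound 3 to compound 4 (0.15 log units; that floor lies within the scatter). The estimate for compound 4 in this assay is 90000 nM, with a range of 25000 nM to 200000 nM.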

Compound 4, half-maximal inhibitory concentration: 99200 nM
The estimate for compound 4 lay 1.1-fold (0.04 log units) below the measured number, within the range that was stated.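

In this assay, compound 4 gives the only measured number among the methoxybenzyl members shown, so the isopropyl urea in this series now has a value rather than a limit. Ethyl to isopropyl reads as an at least 1.2-fold lower number from compound 3 to compound 4 (0.11 log units; that floor lies within the scatter), and going from the unsubstituted urea nitrogen to the isopropyl urea reads as an at least 1.2-fold lower number from compound 2 to compound 4 (0.11 log units; that floor lies within the scatter); both are floors rather than sizes, and the step from compound 2 to compound 3 cannot be read at all, because of the assay limit: the limit of > 128000 nM in this assay, at which 2 of the 4 values shown sit. Methoxy in place of chloro on an aromatic carbon, with the isopropyl urea held, gives a 5.0-fold higher number from compound 1 to compound 4 (0.70 log units; beyond the scatter), the only step here with a number at both ends, which shows that the benzyl substituent changes the read-out at this urea.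

Compound 1 is the only chlorobenzyl member shown, so whether the urea nitrogen substituent matters with that group remains open. Also open, from the compounds shown here alone, is how a longer chain, such as butyl, or an amine on the urea nitrogen would read in this assay.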